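Adding Fluorine to a Styryl Indole: Expected Cytotoxicity

The source may hold more compounds than are shown below. What is called first, only, known or untested is meant among the compounds shown, and "the series" means these compounds.

Compound 1 `CC(=O)c1cc(-c2ccc(F)cc2)cc2cc(-c3ccccc3)[nH]c12` gives 38000 nM in a functional assay on HeLa cells (Homo sapiens) for cytotoxicity, read by MTT assay, with a stated time of 2 days; on this read-out higher numbers stand for lower toxicity in this test and lower numbers for higher toxicity in this test.
Compound 2 `COc1ccc(-c2cc(C(C)=O)c3[nH]c(-c4ccccc4)cc3c2)cc1` gives 15500 nM in this assay.
Compound 3 `CC(=O)c1cc(/C=C/c2ccccc2)cc2cc(-c3ccccc3)[nH]c12` gives 30800 nM in this assay.

Compound 3 stands second highest of the three numbers. Its nearest neighbour is compound 1, with a 1.2-fold lower number from compound 1 to compound 3 (0.09 log units; within the scatter); its furthest is compound 2, with a 2.0-fold higher number from compound 2 to compound 3 (0.30 log units; within the scatter).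

Compound 4 `CC(=O)c1cc(/C=C/c2ccc(F)cc2)cc2cc(-c3ccccc3)[nH]c12` differs from compound 3 in one place: fluoro in place of hydrogen on an aromatic carbon. For the measured compounds named here, no measured step swaps a hydrogen for a fluorine. The closest comparison is a 2.5-fold lower number from compound 1 to compound 2 (0.39 log units; beyond the scatter), a modest shift between two groups on the same kind of ring, while exchanging the whole group produced only changes within the scatter. A step of similar or smaller size is therefore expected: a 1.0-fold lower number from compound 3 to compound 4 (0.01 log units; within the scatter). For compound 4 the estimate is 30000 nM, within a range from 14000 nM to 62000 nM.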

Compound 4, concentration lethal to 50% of the cells: 9260 nM
The estimate for compound 4 lay 3.2-fold (0.51 log units) above the measured number; measured number outside the range, below it.
By their numbers in this assay, from the lowest: compounds 4, 2, 3 and 1 (each within the scatter of the next, the first and the last beyond it).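

In this assay, adding a single fluoro to the phenyl of the 2-phenylethenyl group gives a 3.3-fold lower number from compound 3 to compound 4 (0.52 log units; beyond the scatter) and so shows that this position can respond to a one-atom change. The ethenyl link matters once the fluoro is present: the exchange gives a 4.1-fold lower number from compound 1 to compound 4 (0.61 log units; beyond the scatter) even though compound 3, without fluoro, stays within the scatter of compound 1. The step of a 1.7-fold lower number from compound 2 to compound 4 (0.22 log units; within the scatter) leaves compound 4 indistinguishable from compound 2. Going by these compounds, whether chloro or an amine in the fluoro's place would behave similarly remains open. Nothing available explains the shift.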